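Dropping the Methyl from a Nitroindole Aromatase Inhibitor

The compounds below may be only part of what the source reports. "The series", "measured", "known", "first", "only" and "open" are said of these compounds alone.

Measured compounds:
- Compound 1, `Cc1ccccc1-c1cc2cc([N+](=O)[O-])ccc2[nH]1`: 6870 nM
- Compound 2, `N#Cc1ccc2[nH]c(-c3cccnc3)cc2c1`: 11500 nM

Of the compounds shown here, two sharing the same core have been tested in an assay on isolated protein for inhibition of Aromatase (Homo sapiens), read by fluorescence, using NADPH, with a stated time of 30 min; on this read-out higher numbers stand for weaker inhibition and lower numbers for stronger inhibition. Compound 1 gives 6870 nM, and compound 2 gives 11500 nM. Compound 1 has the lowest of the two numbers, but compound 2 lies within the usual scatter of it, so the two cannot be ranked against each other.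

The next compound, compound 3, `O=[N+]([O-])c1ccc2[nH]c(-c3ccccc3)cc2c1`, differs from compound 1 in one place: hydrogen in place of methyl on an aromatic carbon. For the measured compounds named here, no measured pair shows what such a change does here, so there is no guide from the data. The removal of a single carbon from the periphery is expected to move the number little, in either direction, within or close to the scatter. Compound 3 is therefore expected to give about 5500 nM, in the range 1500 nM to 20000 nM, a step of a 1.2-fold lower number from compound 1 to compound 3 (0.10 log units; within the scatter) from compound 1.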

Compound 3, half-maximal inhibitory concentration: 9000 nM
Estimate against measurement, compound 3: 1.6-fold (0.21 log units) below, and the stated range covers the measured number.
By their numbers in this assay, from the lowest: compounds 1, 3 and 2 (each within the scatter of the next).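

Swapping the methyl for hydrogen on this aromatic carbon, ortho to a large group, gives a 1.3-fold higher number from compound 1 to compound 3 (0.12 log units; within the scatter) in this assay. This first single-place comparison shows that, at this position, the methyl makes no difference that can be told from the ordinary spread of repeat measurements, so compound 1 and compound 3 cannot be ranked against each other. No measurement at hand offers an explanation for this result.

This single pair says nothing about what a different group on this carbon would do, such as an amine, a methoxy group or a chlorine atom. Also open, from the compounds shown here alone, is whether a methyl on one of the other carbons of this ring would behave in the same way.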